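The source may report more compounds than this note shows. Statements on the series, on what has been measured and on what is new or still open speak of the compounds shown alone.

Measured so far in a functional assay on HEK293 cells for antagonist activity at transient receptor potential cation channel subfamily V member 1 (Rattus norvegicus); a higher number here means a weaker inhibitor, a lower number a stronger inhibitor:
Compound 1, `Cc1ccc(NC(=O)N2CCN(c3ncccc3C(F)(F)F)CC2)cc1`, gives 1550 nM.
Compound 2, `CC(C)(C)c1ccc(NC(=S)N2CCN(c3ncccc3C(F)(F)F)CC2)cc1`, gives 441 nM.
Compound 3, `CC(C)c1ccc(NC(=O)N2CCN(c3ncccc3[N+](=O)[O-])CC2)cc1`, gives 245 nM.

Compound 3 has the lowest of the three numbers. Its nearest neighbour is compound 2, whose number lies within the scatter of that of compound 3, so the two cannot be ordered; compound 1 sits higher, beyond the scatter. Compound 4, `CC(C)c1ccc(NC(=O)N2CCN(c3ncccc3Br)CC2)cc1`, differs from compound 3 in one place: bromo in place of nitro on an aromatic carbon. Among the measured compounds shown here, no measured pair isolates this exchange, and bromo occurs in none of the measured compounds, so the step rests on judgement alone. The expectation is a modest move toward weaker inhibition, a 1.8-fold higher number from compound 3 to compound 4 (0.26 log units; within the scatter), close to the edge of the scatter. Compound 4 is accordingly expected at 450 nM, within a range from 130 nM to 1500 nM.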

Compound 4, half-maximal inhibitory concentration: 27.1 nM
Beside the measured number, compound 4's estimate is 17-fold (1.22 log units) above it; the measured number lies below the stated range.
By their numbers in this assay, from the lowest: compound 4; then compounds 3 and 2 (each within the scatter of the next); then compound 1.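

In this assay, bromo in place of nitro on this aromatic carbon, ortho to a large group, gives a 9.0-fold lower number from compound 3 to compound 4 (0.96 log units; beyond the scatter). Among the compounds shown here, this is the first change in one place among the compounds, and it shows that the group on this carbon matters to the number, with the single bromine atom far ahead of the three heavy atoms of nitro. Nothing measured here accounts for the size of this step.

Going by these compounds, it remains open whether chloro, methoxy or an amine on this carbon would match bromo. On these data alone, it is also open whether the exchange gives a similar step with tert-butyl in place of isopropyl.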